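Adding a 4-bromobutyl chain to compound 2

The source may hold more compounds than are shown below. What is called first, only, known or untested is meant among the compounds shown, and "the series" means these compounds.

Of the compounds shown here, two have numbers so far in a functional assay on A549 cells (Homo sapiens) for antiproliferative activity, read by MTT assay, with a stated time of 48 h; a higher number here means a weaker inhibitor, a lower number a stronger inhibitor. Going by the values given here, compound 1 `COc1ccc(N(C)c2ccnc(Cl)n2)cc1Cl` gives 621 nM and compound 2 `COc1ccc(N(C)c2ccnc(Cl)n2)cc1O` gives 381 nM, so the two lie within the scatter of each other and compound 2 does not stand apart from its only measured neighbour.

Compound 3 `COc1ccc(N(C)c2ccnc(Cl)n2)cc1OCCCCBr` keeps the shared core and turns hydroxy into 4-bromobutoxy: 4-bromobutyl in place of hydrogen on an oxygen on an aromatic ring. Among the compounds with values here, only one measured step bears on this change, a 1.6-fold lower number from compound 1 to compound 2 (0.21 log units; within the scatter), which lies within the scatter. That step exchanges chloro for hydroxy and does not test a chain on the oxygen. Within the data shown here, no measured compound carries such a chain, so the data give no direction for this change and only weak guidance on its size. Among the measured compounds shown here, with a 1.6-fold lower number from compound 1 to compound 2 (0.21 log units; within the scatter) as the sole guide, no step beyond the scatter is expected in this assay, though the uncertainty is wide. The expected step is a 1.2-fold higher number from compound 2 to compound 3 (0.07 log units; within the scatter). The estimate for compound 3 is 450 nM, with an expected range from 120 nM to 1700 nM.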

Compound 3, half-maximal inhibitory concentration: 591 nM
Compound 3: middle estimate off by 1.3-fold (0.12 log units), on the low side; low and high end bracket the measured number.
By their numbers in this assay, from the lowest: compounds 2, 3 and 1 (each within the scatter of the next).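

In this assay, going by these compounds alone, the step from hydroxy to 4-bromobutoxy gives a 1.6-fold higher number from compound 2 to compound 3 (0.19 log units; within the scatter), the first reading on a chain at this oxygen on an aromatic ring: with 4-bromobutyl in place of hydrogen, the free hydroxy hydrogen is not needed for a number in this range. The comparison with the chloro compound gives a 1.1-fold lower number from compound 1 to compound 3 (0.02 log units; within the scatter), so chloro, hydroxy and 4-bromobutoxy at this place all lie within the scatter of one another and none of the three stands apart in this assay. No measured evidence bears on this result, and the numbers alone give no account of it.

The compounds shown do not separate the butyl chain from its terminal bromine, so a plain butyl chain, or the same chain ending in an amine or a carboxylic acid, remains an open comparison. Also open, as far as these compounds go, is whether a shorter or longer chain on this oxygen would give a step beyond the scatter in either direction.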